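A few compounds are considered here, and "the series" means these few. Any claim that something is new, unique, unknown or untested is made for them only; others in the source may bear on it.

In a functional assay on L1210 cells (Mus musculus) for antiproliferative activity, read by MTT assay; on this read-out lower numbers stand for stronger inhibition and higher numbers for weaker inhibition:
- Compound 1 `O=C(N/N=C/c1ccccc1[N+](=O)[O-])c1cn(C2CC2)c2cc(N/N=C/c3ccccc3[N+](=O)[O-])c(F)cc2c1=O`: <= 25000 nM, a limit
- Compound 2 `O=C(N/N=C/c1ccccc1)c1cn(C2CC2)c2cc(N3CCNCC3)c(F)cc2c1=O`: <= 25000 nM, a limit
- Compound 3 `COc1cc(/C=N/NC(=O)c2cn(C3CC3)c3cc(N4CCNCC4)c(F)cc3c2=O)cc(OC)c1OC`: <= 25000 nM, a limit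

Compound 3 offers only a limit, <= 25000 nM, and no exact number. The whole set so far rests on (the limit of <= 25000 nM in this assay, at which 3 of the 3 values shown sit). Compound 4 `O=C(N/N=C/c1ccccc1[N+](=O)[O-])c1cn(C2CC2)c2cc(N3CCNCC3)c(F)cc2c1=O` has 2-nitrophenyl in place of 3,4,5-trimethoxyphenyl on a carbon with a double bond to nitrogen.

Going by the values given here, the only measured step at this place is a step that the two limits leave unreadable from compound 2 to compound 3, so it gives no usable size. Compound 1 also carries 2-nitrophenyl, and it too gives a limit, <= 25000 nM. No step beyond the scatter, in either direction, is therefore expected in this assay.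

The expected change is a step that the limit leaves unreadable from compound 3 to compound 4. The estimate for compound 4 is 15000 nM, with an expected range from 4000 nM to 25000 nM.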

Compound 4, half-maximal inhibitory concentration: <= 25000 nM
Compound 4: only a limit was reported; the forecaster's own chance of this, stated with the estimate: 75%; the middle value lies beyond the limit too.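

Compound 4 gives only a limit, so its steps from compound 1, compound 2 and compound 3 cannot be read: the limit of <= 25000 nM in this assay, at which 4 of the 4 values shown sit.

The compounds shown leave open how strongly each acts in this assay and whether exchanging 3,4,5-trimethoxyphenyl for 2-nitrophenyl changes anything.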